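From 3-nitrophenyl to 3,5-dimethylphenyl on the shared core

The source may hold more compounds than are shown below. What is called first, only, known or untested is meant among the compounds shown, and "the series" means these compounds.

Among the compounds with values here, in an ADME assay on HEK-293T cells (Homo sapiens) for cytotoxicity, read by CCK-8 assay, with a stated time of 48 h (a higher number here means a weaker inhibitor, a lower number a stronger inhibitor), compound 2 (`O=C(NCCNS(=O)(=O)c1ccc(-c2ccccc2OCc2ccccc2)s1)Nc1cccc([N+](=O)[O-])c1`) gives 13300 nM as the only actual number so far. Compound 1 (`COc1cccc(NC(=O)NCCNS(=O)(=O)c2ccc(-c3ccccc3OCc3ccccc3)s2)c1`) reads > 20000 nM in this assay and this is a limit of the assay, not a number. Next comes compound 3 (`Cc1cc(C)cc(NC(=O)NCCNS(=O)(=O)c2ccc(-c3ccccc3OCc3ccccc3)s2)c1`), with 3,5-dimethylphenyl in place of 3-nitrophenyl on an amide-type nitrogen. Within the data shown here, the only measured step bearing on this is nitro in place of methoxy on an aromatic carbon (an at least 1.5-fold lower number from compound 1 to compound 2 (0.17 log units; that floor lies within the scatter)) and it does not test 3,5-dimethylphenyl itself. With the nitro leaving again, that step of compound 2 gives only a weak lean towards a higher number. The expected step is small and stays within the scatter (a 1.2-fold higher number from compound 2 to compound 3 (0.08 log units; within the scatter)) in this assay. For compound 3 the estimated value is 16000 nM with an expected range from 8000 nM to 30000 nM in this assay for now.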

Compound 3, half-maximal inhibitory concentration: > 20000 nM
Compound 3 was reported as a limit; the forecaster's own chance of this, stated with the estimate: 40%; at least 1.2-fold (0.09 log units) between middle value and limit.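

The change from 3-nitrophenyl to 3,5-dimethylphenyl on an amide-type nitrogen gives an at least 1.5-fold higher number from compound 2 to compound 3 (0.17 log units; that floor lies within the scatter). On these data alone, this is only a floor, so the true size of the step in this assay remains unknown. Within the data shown here, compound 3 is reported as a limit, so compound 2 remains the only compound of the three with an actual number, and the step that joins the two limited compounds cannot be read. The series now rests mostly on that assay ceiling: the limit of > 20000 nM in this assay, at which 2 of the 3 values shown sit.

As far as these compounds go, how far compound 1 and compound 3 lie past the limit remains open. Also open, from the compounds shown here alone, is whether an amine or a carboxylic acid in place of the nitro group of compound 2 would give a number that stands clear of the scatter.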